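From fluoro to chloro on compound 2

The compounds below may be only part of what the source reports. "The series", "measured", "known", "first", "only" and "open" are said of these compounds alone.

For the measured compounds named here, only two compounds have been measured so far in an ADME assay for permeability, using PAMPA, at pH 7.4 (a higher number here means that the compound crosses the layer faster, a lower number that the compound crosses the layer more slowly), of this series. Compound 1 (`O=C(Nc1ccc(F)c(-c2nc3ccccc3o2)c1)c1cc([N+](=O)[O-])ccc1Cl`) gives 366 10^-6 cm/s and compound 2 (`O=C(Nc1ccc(F)c(-c2nc3ccccc3s2)c1)c1cc([N+](=O)[O-])ccc1Cl`) gives 17 10^-6 cm/s as the lower of the two numbers. Compound 3 (`O=C(Nc1ccc(Cl)c(-c2nc3ccccc3s2)c1)c1cc([N+](=O)[O-])ccc1Cl`) is still unmeasured. Its difference from compound 2 (chloro in place of fluoro on an aromatic carbon) is chloro in place of fluoro on an aromatic carbon, ortho to a 1,3-benzothiazol-2-yl group and para to a large group.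

Going by the values given here, the only measured step (a 22-fold lower number from compound 1 to compound 2 (1.33 log units; beyond the scatter)) was large and beyond the scatter. However, it exchanged 1,3-benzoxazol-2-yl for 1,3-benzothiazol-2-yl, a different group from the one changing now, so it gives no direct guide to this swap. It does show that a single change can move the number a long way in this pair. Among the compounds with values here, no fluoro-to-chloro step has been measured here, so no shift beyond the scatter is expected in this assay and the range is kept wide. The expected step is a small one (a 1.2-fold lower number from compound 2 to compound 3 (0.08 log units; within the scatter)). For compound 3 the estimated value is 14 10^-6 cm/s with an expected range from 5 10^-6 cm/s to 45 10^-6 cm/s in this measurement.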

Compound 3, apparent permeability: 3 10^-6 cm/s
Compound 3: middle estimate off by 4.7-fold (0.67 log units), on the high side; the whole stated range lies above it.
By their numbers in this assay, from the lowest: compound 3; then compound 2; then compound 1.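

In this assay, chloro in place of fluoro on an aromatic carbon, ortho to a 1,3-benzothiazol-2-yl group and para to a large group, gives a 5.7-fold lower number from compound 2 to compound 3 (0.75 log units; beyond the scatter). This position is therefore not a silent one: exchanging a single halogen atom here moves the number beyond the scatter, which the earlier pair could not show because its change lay in a different group, with a 22-fold lower number from compound 1 to compound 2 (1.33 log units; beyond the scatter). No measurement shown here explains why the number falls with this swap.

For the compounds shown here, how an amine, a methoxy group or a nitrile at this position would read in this assay remains open, so two halogens give only a first look at what this place tolerates and no trend across groups. As far as these compounds go, it is also open whether the same swap of fluoro for chloro would give a step of similar size with 1,3-benzoxazol-2-yl in place of 1,3-benzothiazol-2-yl, since the step is known only with the latter group present.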